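The compounds below may be only part of what the source reports. "The series", "measured", "known", "first", "only" and "open" are said of these compounds alone.

Measured compounds:
compound 1 `C#CCNC1CCc2c(SCCc3cccc(Br)c3)cccc21`, in an ADME assay on isolated protein for inhibition of Amine oxidase [flavin-containing] B (Homo sapiens) (on this read-out lower numbers stand for stronger inhibition and higher numbers for weaker inhibition), compound 1 gives 620 nM
compound 2 `C#CCNC1CCc2c(SCCc3cccc(C)c3)cccc21`, in this assay compound 2 gives 4960 nM
compound 3 `C#CCNC1CCc2c(SCc3ccc(C(F)(F)F)cc3)cccc21`, in this assay compound 3 gives 930 nM

Compound 2 stands highest of the three numbers in this assay; compound 3 is nearest to it and compound 1 furthest, and both of those gaps lie beyond the scatter. Compound 4 `C#CCNC1CCc2c(SCCc3cccc(OC)c3)cccc21` has not yet been measured. It differs from compound 2 in one place: methoxy in place of methyl on an aromatic carbon.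

Within the data shown here, only one measured step is a single change at this same position, and it does not involve methoxy. That step, an 8.0-fold higher number from compound 1 to compound 2 (0.90 log units; beyond the scatter), shows that the group on this aromatic carbon can shift the number well beyond the scatter. Compound 3 differs from compound 2 in more than one place, so its value serves only as a second point of comparison. Nothing measured here tells how methoxy itself behaves at this position.

Among the measured compounds shown here, with no direct precedent, the account expects compound 4 to return a number near that of compound 2, with a lean toward a somewhat lower number, a step of a 1.4-fold lower number from compound 2 to compound 4 (0.15 log units; within the scatter), and the expectation is held loosely. The estimate for compound 4 in this assay is 3500 nM, with a range from 1200 nM to 10000 nM.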

Compound 4, half-maximal inhibitory concentration: 3820 nM
Compound 4: the middle estimate sits 1.1-fold (0.04 log units) below what was measured, within the range that was stated.
By their numbers in this assay, from the lowest: compounds 1 and 3 (each within the scatter of the next); then compounds 4 and 2 (each within the scatter of the next).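

On this aromatic carbon of the 3-substituted phenyl ring, methoxy in place of methyl gives a 1.3-fold lower number from compound 2 to compound 4 (0.11 log units; within the scatter), so in this assay this change, which adds one oxygen and one hydrogen-bond acceptor, cannot be told from no change at all. Among these compounds, the earlier compounds showed only that the position responds to one exchange, whereas a 6.2-fold higher number from compound 1 to compound 4 (0.79 log units; beyond the scatter) now joins an 8.0-fold higher number from compound 1 to compound 2 (0.90 log units; beyond the scatter) and sets bromo apart from two other groups instead of one, with compound 1 the only one of these three compounds on the lower side of the scatter. Nothing at hand explains why bromo parts from methyl and methoxy in this way.

Going by these compounds, three groups at one position cannot show what the separation of bromo depends on, and it remains open whether chloro, iodo, an amine or a carboxylic acid on this carbon would fall with compound 1 or with compound 2 and compound 4. On these data alone, it is equally open whether a longer chain such as ethoxy would stay within the scatter of methoxy in this assay.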